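Removing the chloro from the longer-chain amide

The source may report more compounds than this note shows. Statements on the series, on what has been measured and on what is new or still open speak of the compounds shown alone.

Two compounds of this series have numbers. Compound 1 `O=C(CCc1ccccc1)Nc1nc2ccccc2c(=O)s1` gives 390 nM in an assay on CHO cells for displacement of a labelled ligand from adenosine receptor A3 (Homo sapiens), read by scintillation counting, with a stated time of 60 min; a lower number here means a stronger inhibitor, a higher number a weaker inhibitor. Compound 2 `O=C(CCCc1ccccc1)Nc1nc2ccc(Cl)cc2c(=O)s1`, which carries a longer chain and a chloro on the fused ring, returns only a limit in this assay, > 1000 nM. Compound 2 therefore stands at the limit of > 1000 nM in this assay, at which 1 of the 2 values shown sits, and no number is known for it. Compound 3 `O=C(CCCc1ccccc1)Nc1nc2ccccc2c(=O)s1` has not been measured in this assay. The change from compound 2 to compound 3 is hydrogen in place of chloro on an aromatic carbon. Going by the values given here, no measured step covers this change. Compound 1, which also lacks the chloro and gives 390 nM in this assay, has a shorter chain than compound 3, so compound 3 is expected to land between compound 1 and compound 2. For compound 3 the expected value in this assay is 900 nM, with a range from 300 nM to 3000 nM. This means an expected step of an at least 1.1-fold lower number from compound 2 to compound 3 (0.04 log units; that floor lies within the scatter).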

Compound 3, inhibition constant: > 1000 nM
Compound 3: no number, only a limit; the forecaster's own chance of this, stated with the estimate: 40%; at least 1.1-fold (0.04 log units) between middle value and limit.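

In this assay compound 3 returns only a limit, > 1000 nM, and not a number. Both ends of the change from chloro to hydrogen are limits, and that step cannot be read, so this position on the aromatic ring gives no readable effect. The readable change lies in the chain, where benzyl in place of phenyl, with no chloro on either compound, gives an at least 2.5-fold higher number from compound 1 to compound 3 (0.40 log units; beyond the scatter), and the series now reaches its limit without the chloro: the limit of > 1000 nM in this assay, at which 2 of the 3 values shown sit.

From the compounds shown here alone, how far the number rises with the longer chain remains open, as does what a chloro would do on the shorter chain. Also open, going by these compounds, is whether an amine or a carboxylic acid at the end of the chain, in place of the phenyl, would give a stronger inhibitor in this assay.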